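Moving the Fluorine on the Benzyl Group

The source may report more compounds than this note shows. Statements on the series, on what has been measured and on what is new or still open speak of the compounds shown alone.

Compound 1 `CS(=O)(=O)c1ccc(-n2ccc3cnc(Nc4cnn(CCCCCC(=O)NO)c4)nc32)cc1` gives 10.8 nM in an assay on isolated protein for inhibition of protein deacetylase HDAC6 (Homo sapiens), with a stated time of 60 min; on this read-out higher numbers stand for weaker inhibition and lower numbers for stronger inhibition.
Compound 2 `O=C(CCCCCn1cc(Nc2ncc3ccn(Cc4ccccc4)c3n2)cn1)NO` gives 13.8 nM in this assay.
Compound 3 `O=C(CCCCCn1cc(Nc2ncc3ccn(Cc4ccccc4F)c3n2)cn1)NO` gives 15.3 nM in this assay.

The three measured compounds share a core carrying a hydroxamic acid on a chain, and differ only in the group on the aromatic nitrogen. Compound 3 has the highest number of the three, but its step from compound 2, a 1.1-fold higher number from compound 2 to compound 3 (0.04 log units; within the scatter), and the step of a 1.4-fold higher number from compound 1 to compound 3 (0.15 log units; within the scatter) both lie within the scatter, so none of the three can be called stronger or weaker than another.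

Compound 4 `O=C(CCCCCn1cc(Nc2ncc3ccn(Cc4cccc(F)c4)c3n2)cn1)NO` differs from compound 3 in one place: 3-fluorophenyl in place of 2-fluorophenyl on a saturated chain carbon bound to an aromatic nitrogen. The nearest measured step is a 1.1-fold higher number from compound 2 to compound 3 (0.04 log units; within the scatter), where adding a fluorine to the benzyl group changed little; the larger swap a 1.3-fold higher number from compound 1 to compound 2 (0.11 log units; within the scatter) also stayed within the scatter. Moving the fluorine is therefore expected to give a step of a 1.0-fold lower number from compound 3 to compound 4 (0.01 log units; within the scatter) in this assay that does not exceed the scatter. Compound 4 is estimated at 15 nM, with a range from 7 nM to 32 nM.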

Compound 4, half-maximal inhibitory concentration: 13.7 nM
Beside the measured number, compound 4's estimate is 1.1-fold (0.04 log units) above it; low and high end bracket the measured number.
By their numbers in this assay, from the lowest: compounds 1, 4, 2 and 3 (each within the scatter of the next).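

In this assay, moving the fluorine around the benzyl ring gives a 1.1-fold lower number from compound 3 to compound 4 (0.05 log units; within the scatter) and the 3-fluorobenzyl group compared with plain benzyl gives a 1.0-fold lower number from compound 2 to compound 4 (0.00 log units; within the scatter), so with no fluorine or with fluorine in either of two placements, the number stays within the scatter. Exchanging the 4-(methylsulfonyl)phenyl group for 3-fluorobenzyl gives a 1.3-fold higher number from compound 1 to compound 4 (0.10 log units; within the scatter), also within the scatter, so these quite different groups on the aromatic nitrogen cannot be told apart in this assay. Nothing available explains why these compounds read so alike.

As far as these compounds go, it remains open whether a benzyl group carrying a methoxy group or an amine in place of the fluorine would also stay within the scatter. From the compounds shown here alone, it is equally open how a shorter chain leading to the hydroxamic acid would read.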